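The compounds below may be only part of what the source reports. "The series", "measured", "known", "first", "only" and "open" are said of these compounds alone.

Compound 1 `COc1cc(Oc2cccc(Nc3ccccc3)c2)cc(OC)c1CNCc1ccc(Br)cc1`: in a functional assay on HCT-116 cells (Homo sapiens) for inhibition, read by MTT assay, with a stated time of 72 h (on this read-out higher numbers stand for weaker inhibition and lower numbers for stronger inhibition), compound 1 gives 6230 nM.
Compound 2 `CNCc1c(OC)cc(Oc2cccc(Nc3ccccc3)c2)cc1OC`: compound 2 gives only the assay limit > 20000 nM.
Compound 3 `COc1cc(Oc2cccc(Nc3ccccc3)c2)cc(OC)c1CNC(C)C`: compound 3 gives only the assay limit > 20000 nM.

Among these three, compound 1 is the only one with an actual number; the other two sit at the limit of > 20000 nM in this assay, at which 2 of the 3 values shown sit, so compound 1 is the only fixed point from which any step can be read.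

Compound 4 `COc1cc(Oc2cccc(Nc3ccccc3)c2)cc(OC)c1CNCc1ccccc1` differs from compound 1 in one place: hydrogen in place of bromo on an aromatic carbon. For the measured compounds named here, no measured step removes the bromo alone. The nearest comparisons are an at least 3.2-fold higher number from compound 1 to compound 2 (0.50 log units; beyond the scatter) and an at least 3.2-fold higher number from compound 1 to compound 3 (0.50 log units; beyond the scatter), in which the whole 4-bromobenzyl group is removed or replaced and inhibition weakens beyond the scatter. How much of that weakening belongs to the bromo itself, as opposed to the rest of the benzyl group, cannot be separated from these two steps alone.

Keeping the benzyl group while dropping only the bromo is therefore expected to cost less than either of those steps, a step of a 1.8-fold higher number from compound 1 to compound 4 (0.25 log units; within the scatter) toward weaker inhibition. Compound 4 is estimated at 11000 nM, within a range from 4000 nM to 20000 nM.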

Compound 4, half-maximal inhibitory concentration: 4070 nM
For compound 4 the middle estimate is 2.7-fold (0.43 log units) above the measured one, and the stated range covers the measured number.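

In this assay, taking off the bromo gives a 1.5-fold lower number from compound 1 to compound 4 (0.18 log units; within the scatter), so the activity of compound 1 does not depend on the bromo. The benzyl group alone still counts: benzyl in place of isopropyl on the amine nitrogen gives an at least 4.9-fold lower number from compound 3 to compound 4 (0.69 log units; beyond the scatter), and phenyl in place of hydrogen on the chain carbon gives an at least 4.9-fold lower number from compound 2 to compound 4 (0.69 log units; beyond the scatter). Among these compounds, the weakening seen earlier therefore goes with losing the phenyl ring of the benzyl group, not the bromo, and both of these last steps are only minimum sizes, since compounds 2 and 3 have a limit rather than a number: the limit of > 20000 nM in this assay, at which 2 of the 4 values shown sit.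

From the compounds shown here alone, it remains open whether a chlorine or a methoxy group at the bromo's place would move the number beyond the scatter. A longer chain between the amine nitrogen and the phenyl ring is equally untested here.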